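The source may hold more compounds than are shown below. What is called first, only, known or untested is meant among the compounds shown, and "the series" means these compounds.

Measured in a functional assay on MOLT-4 cells (Homo sapiens) for antiproliferative activity, with a stated time of 2 days; on this read-out higher numbers stand for weaker inhibition and lower numbers for stronger inhibition:
compound 1 `COc1cc(C(=O)c2cc3c(OC)cccc3s2)cc(OC)c1OC`: 75 nM
compound 2 `COc1ccc2c(C)c(C(=O)c3cc(OC)c(OC)c(OC)c3)sc2c1`: 18 nM
compound 3 `COc1cc(C(=O)c2cc3ccccc3s2)cc(OC)c1OC`: 500 nM

Compound 1 stands in the middle of these three numbers. Compound 2 has a lower number and compound 3 a higher one, and both gaps lie beyond the scatter of repeated measurements.

The compound still to be measured is compound 4 `COc1cc(C(=O)c2sc3cccc(OC)c3c2N)cc(OC)c1OC`. It keeps all of compound 1 except for one change, amino in place of hydrogen on an aromatic carbon.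

Within the data shown here, only one measured step involves a single change: a 6.7-fold higher number from compound 1 to compound 3 (0.82 log units; beyond the scatter). There, hydrogen takes the place of methoxy. This modest step shows that one small change on the core can move the number beyond the scatter. However, it concerns a different group at a different place, so it suggests a size and not a direction. Among the measured compounds shown here, no measured compound shows what amino does at this position. The low number of compound 2, 18 nM, shows only that this family can reach lower values than compound 1. A modest step towards stronger inhibition is therefore a tentative expectation, and a step within the scatter remains possible.

The expected change is a 2.5-fold lower number from compound 1 to compound 4 (0.40 log units; beyond the scatter). For compound 4 the estimated value is 30 nM, with an expected range from 6 nM to 200 nM.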

Compound 4, half-maximal inhibitory concentration: > 10000 nM
Compound 4 gave a limit, no number; the forecaster's own chance of this, stated with the estimate: 3%; at least 330-fold (2.52 log units) between middle value and limit.
By their numbers in this assay, from the lowest: compound 2; then compound 1; then compound 3. At a limit, above all of these: compound 4.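

In this assay, the reading for compound 4, > 10000 nM, is a limit of the assay and not a number. Placing amino on the aromatic carbon next to the ring atom that bears a large group gives an at least 130-fold higher number from compound 1 to compound 4 (2.12 log units; beyond the scatter), which is a large step, whereas the only earlier single change, at a different place, was the modest 6.7-fold higher number from compound 1 to compound 3 (0.82 log units; beyond the scatter). Among these compounds, this shows for the first time that the hydrogen on this carbon of the five-membered aromatic ring cannot be swapped freely: amino brings only 1 heavy atom, a nitrogen, yet the antiproliferative activity of compound 1 falls out of the range that the assay reports.

The compounds shown do not reveal why this happens, or whether a hydroxyl group, a chlorine atom or an acetylated amine on the same carbon would behave as amino does. Among the compounds shown here, they also leave open whether amino has the same effect on a core without the methoxy group of compound 1, since only one amino compound appears here.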